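The compounds below may be only part of what the source reports. "The series", "measured", "known", "first", "only" and "open" are said of these compounds alone.

Compound 1 `CC(C)(C)N(NC(=O)c1ccccc1)C(=O)c1ccccc1Br` and compound 2 `CC(C)(C)N(NC(=O)c1ccccc1)C(=O)c1ccccc1I` share a core and differ in one place: in compound 2 iodo stands in place of bromo (iodo in place of bromo on an aromatic carbon). In an assay on cells for agonist activity at ecdysone receptor (Bombyx mori), read by a luciferase reporter, with a stated time of 24 h (a higher number here means that more compound is needed for the effect, a lower number that less compound is needed), compound 1 gives 170 nM, while compound 2 gives 105 nM; the step is a 1.6-fold lower number from compound 1 to compound 2 (0.21 log units; within the scatter). Compound 3 `CC(C)(C)N(NC(=O)c1ccc(Br)cc1)C(=O)c1ccccc1Cl` has a different core, and the difference between the two cores is not broken down here. In this assay compound 3 gives 33.9 nM, the lowest of the three numbers, with both other compounds beyond the scatter from it.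

Compound 4 `CC(C)(C)N(NC(=O)c1ccc(I)cc1)C(=O)c1ccccc1Cl` has not yet been measured. It differs from compound 3 by the same kind of change, iodo in place of bromo (iodo in place of bromo on an aromatic carbon), but here the place is para to a large group, whereas in compound 2 the place is ortho to a large group. Because compound 1 to compound 2 moved only by a 1.6-fold lower number from compound 1 to compound 2 (0.21 log units; within the scatter), a step of similar modest size is expected from compound 3 to compound 4, namely a 1.4-fold lower number from compound 3 to compound 4 (0.13 log units; within the scatter). Compound 4 is therefore estimated to give 25 nM in this assay, within a range from 11 nM to 60 nM.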

Compound 4, half-maximal effective concentration: 7.59 nM
For compound 4 the middle estimate is 3.3-fold (0.52 log units) above the measured one, outside the stated range (below it).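

In this assay, iodo in place of bromo on the 4-bromophenyl group gives a 4.5-fold lower number from compound 3 to compound 4 (0.65 log units; beyond the scatter), and this step does not match the one seen for the same change on the core of compound 1: the same change on two cores in this assay, a 1.6-fold lower number (0.21 log units; within the scatter) from compound 1 to compound 2 and a 4.5-fold lower number (0.65 log units; beyond the scatter) from compound 3 to compound 4, 2.8-fold (0.44 log units) apart, beyond the scatter of two such steps. The size of the step therefore did not carry over from one core to the other in this series, and since only the new step lies beyond the scatter, the two pairs do not establish a shared direction either. They also do not show what sets the steps apart, as the change sits in a different place in each pair and the cores differ as well, so two pairs cannot separate these factors.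

The compounds shown leave open whether a group other than a halogen, such as a nitrile, a methoxy group or a trifluoromethyl group, would be tolerated where the iodo of compound 4 stands. They also leave open how iodo in place of bromo would behave on further cores.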